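This account rests on a few compounds, and the source may have more. Where it says the series, first, only, none or still open, it means among the compounds named here.

Measured so far:
compound 1 `CCOC(=O)[C@H](CCC(=O)O)NC(=O)c1ccc(CNc2nc3cc(N)cc(N)c3nc2-c2ccccc2)cc1` — in a functional assay on HCT-15 cells (Homo sapiens) for inhibition, read by sulforhodamine B assay, with a stated time of 48 h (a lower number here means a stronger inhibitor of growth, a higher number a weaker inhibitor of growth), compound 1 gives 47900 nM
compound 2 `Nc1cc(N)c2nc(-c3ccccc3)c(NCc3ccc(Cl)c(Cl)c3)nc2c1` — in this assay compound 2 gives 4680 nM
compound 3 `COc1ccc(CNc2nc3cc(N)cc(N)c3nc2-c2ccccc2)cc1OC` — in this assay compound 3 gives 30200 nM

Compound 3 stands second highest of the three numbers. Its nearest neighbour is compound 1, within the scatter; its furthest is compound 2, beyond the scatter. For the measured compounds named here, the only one-point step measured so far is a 6.5-fold higher number from compound 2 to compound 3 (0.81 log units; beyond the scatter), an exchange of 3,4-dichlorophenyl for 3,4-dimethoxyphenyl on the saturated chain carbon bound to the ring nitrogen.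

Compound 4 `COc1cc(CNc2nc3cc(N)cc(N)c3nc2-c2ccccc2)cc(OC)c1OC` differs from compound 3 by methoxy in place of hydrogen on an aromatic carbon. Going by the values given here, no measured step adds a methoxy group to a ring that already carries two, so the measured step bears on this change only indirectly: it shows that the methoxy-bearing ring sits at the weak end of the series. A third methoxy is not expected to move the number beyond the scatter in either direction, so a 1.2-fold higher number from compound 3 to compound 4 (0.06 log units; within the scatter) is the expected step. The estimate for compound 4 in this assay is 35000 nM, with a range from 12000 nM to 100000 nM.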

Compound 4, concentration for 50% growth inhibition: 3240 nM
Compound 4: middle estimate off by 11-fold (1.03 log units), on the high side; measured number outside the range, below it.
By their numbers in this assay, from the lowest: compounds 4 and 2 (each within the scatter of the next); then compounds 3 and 1 (each within the scatter of the next).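

In this assay, methoxy in place of hydrogen on an aromatic carbon, ortho to a methoxy group and meta to a large group, gives a 9.3-fold lower number from compound 3 to compound 4 (0.97 log units; beyond the scatter). For the compounds shown here, a single added group at this position therefore moves the number beyond the scatter, which the earlier compounds did not show. Methoxy groups on this ring do not in themselves mark a weak compound, so a 6.5-fold higher number from compound 2 to compound 3 (0.81 log units; beyond the scatter) describes the exchange for 3,4-dimethoxyphenyl only and not every methoxy-bearing ring; nothing measured here accounts for the size of either step.

Going by these compounds, it remains open whether the step at this position depends on the two methoxy groups already on the ring. On these data alone, it is also open whether a hydroxy group, a fluorine atom or an amine there would give a step of similar size.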